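Methoxy for Methyl, Carried onto a Second Core

A few compounds are considered here, and "the series" means these few. Any claim that something is new, unique, unknown or untested is made for them only; others in the source may bear on it.

Compound 1 `CCOC(=O)c1csc2nc(CN3CCN(C)CC3)c(-c3ccc(C)cc3)n12` gives 53600 nM in a functional assay on HepG2 cells (Homo sapiens) for antiproliferative activity, read by MTT assay, with a stated time of 72 h; on this read-out higher numbers stand for weaker inhibition and lower numbers for stronger inhibition.
Compound 2 `CCOC(=O)c1csc2nc(CN3CCN(C)CC3)c(-c3ccc(OC)cc3)n12` gives 68400 nM in this assay.
Compound 3 `Cc1ccc(-c2c(CN3CCCCC3)nc3scc(C(=O)O)n23)cc1` gives 10800 nM in this assay.

Compounds 1 and 2 share one core and differ in one place, (methoxy in place of methyl on an aromatic carbon). That change made a step of a 1.3-fold higher number from compound 1 to compound 2 (0.11 log units; within the scatter). Compound 3 stands on a different core; the difference between the two cores is not broken down here. Of the three measured numbers, compound 3 has the lowest, and its steps to compound 1 and to compound 2 both lie beyond the scatter.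

Compound 4 `COc1ccc(-c2c(CN3CCCCC3)nc3scc(C(=O)O)n23)cc1` has not yet been measured. Within the data shown here, it differs from compound 3 by methoxy in place of methyl on an aromatic carbon, the same change as the one between compound 1 and compound 2, at the same kind of place. Among the measured compounds shown here, since that change gave only a 1.3-fold higher number from compound 1 to compound 2 (0.11 log units; within the scatter), a step of about the same size is expected from compound 3 to compound 4, namely a 1.2-fold higher number from compound 3 to compound 4 (0.08 log units; within the scatter), resting on the single earlier example. Compound 4 is therefore estimated at 13000 nM in this assay, with a range from 6000 nM to 30000 nM.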

Compound 4, half-maximal inhibitory concentration: 75100 nM
Compound 4: the middle estimate sits 5.8-fold (0.76 log units) below what was measured; measured number above the stated range.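

On the core of compound 3, the move from 4-methylphenyl to 4-methoxyphenyl in this assay gave a 7.0-fold higher number from compound 3 to compound 4 (0.84 log units; beyond the scatter) and so cost far more than it had on the core of compound 1. The step therefore did not carry over at the same size, and the two cores part clearly on this change: the same change on two cores in this assay, a 1.3-fold higher number (0.11 log units; within the scatter) from compound 1 to compound 2 and a 7.0-fold higher number (0.84 log units; beyond the scatter) from compound 3 to compound 4, 5.4-fold (0.74 log units) apart, beyond the scatter of two such steps. This shows that, among these four compounds, the size of the step on one core could not be read across to the other, but with a single pair on each core it does not show which part of the core difference goes with the gap, nor how the change would behave on any further core.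

The compounds shown leave open whether the carboxylic acid or the piperidine of compound 3 is the part that goes with the larger step, since no pair here separates them from the ethyl ester and the methylpiperazine of compound 1. They also leave open whether a chlorine or an ethyl group in that same place would split between the two cores in the same way.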